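This account rests on a few compounds, and the source may have more. Where it says the series, first, only, none or still open, it means among the compounds named here.

Of the compounds shown here, three sharing one core have been tested in an ADME assay on HEK293 cells (Homo sapiens) for cytotoxicity, read by luminescence, with a stated time of 72 h; a higher number here means that more compound is needed for the effect, a lower number that less compound is needed. Compound 1 `CCOC(=O)c1c(-c2cccc(OC(F)(F)F)c2)[nH]c2cc(OC)ccc2c1=O` carries a trifluoromethoxy group. In this assay compound 1 reaches only the limit > 22000 nM, a boundary of the measurement rather than a number. Compound 2 `CCOC(=O)c1c(-c2cccc(C(F)(F)F)c2)[nH]c2cc(OC)ccc2c1=O` differs from it by trifluoromethyl in place of trifluoromethoxy on an aromatic carbon. In this assay compound 2 likewise stops at the limit > 22000 nM. The step that the two limits leave unreadable from compound 1 to compound 2 therefore cannot be read. Compound 3 `CCOC(=O)c1c(-c2cccc(OC)c2)[nH]c2cc(OC(F)(F)F)ccc2c1=O` is built from the same atoms as compound 1 joined differently; the difference between the two cores is not broken down here. In this assay compound 3 also gives the limit > 22000 nM. All three values rest at the same boundary (the limit of > 22000 nM in this assay, at which 3 of the 3 values shown sit).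

Compound 4 `CCOC(=O)c1c(-c2cccc(OC)c2)[nH]c2cc(C(F)(F)F)ccc2c1=O` has not yet been measured. It differs from compound 3 by trifluoromethyl in place of trifluoromethoxy on an aromatic carbon. This is the same kind of change as from compound 1 to compound 2, but its place is not the same: here the group sits on a six-membered aromatic ring of carbon only, part of a fused or bridged system of two rings, meta to a fused ring and para to a fused ring, whereas earlier it sat on a ring meta to a large group. Within the data shown here, because every value so far sits at the boundary (the limit of > 22000 nM in this assay, at which 3 of the 3 values shown sit), the expected step that the limit leaves unreadable from compound 3 to compound 4 is estimated to be small and largely unreadable. Compound 4 is expected to give about 30000 nM, estimated between 15000 nM and 100000 nM, most likely reported again as a limit.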

Compound 4, half-maximal effective concentration: > 22000 nM
Compound 4 was reported as a limit (the forecaster's own chance of this, stated with the estimate: 85%); the middle value does not contradict the limit.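

Compound 4 ends at the same limit as compound 3, so the size of the step from trifluoromethoxy to trifluoromethyl between these two compounds cannot be read, because neither gives an actual number: the limit of > 22000 nM in this assay, at which 4 of the 4 values shown sit. The compounds shown leave open how much of each is needed for the effect in this assay, and whether trifluoromethyl in place of trifluoromethoxy changes that amount at either place.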